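Stability of a sulfonylamide series: urea to benzylamine

The source may report more compounds than this note shows. Statements on the series, on what has been measured and on what is new or still open speak of the compounds shown alone.

Compound 1 `CCS(=O)(=O)NC(=O)c1ccc(Nc2nc(NC3(c4ccc(Cl)cc4)CC3)nc(OCC(F)(F)F)n2)cc1` — 85%
Compound 2 `CNC(=O)NCCS(=O)(=O)NC(=O)c1ccc(Nc2nc(NC3(c4ccc(Cl)cc4)CC3)nc(OCC(F)(F)F)n2)cc1` — 100%
Compound 3 `CC(C)NC(=O)NCCS(=O)(=O)NC(=O)c1ccc(Nc2nc(NC3(c4ccc(Cl)cc4)CC3)nc(OCC(F)(F)F)n2)cc1` — 97%

All three were measured in an ADME assay on microsomes from liver (Rattus norvegicus) for metabolic stability, with a stated time of 10 min; on this read-out higher numbers stand for a more stable compound and lower numbers for a less stable compound. Compound 3 stands second highest of the three: its value lies within the scatter of that of compound 2, and beyond the scatter above that of compound 1. The two measured steps that touch this region both add a urea to the chain: a number 15 percentage points higher from compound 1 to compound 2 (beyond the scatter) and a number 12 percentage points higher from compound 1 to compound 3 (beyond the scatter), each modest. The step of a number 3 percentage points lower from compound 2 to compound 3 (within the scatter) shows that exchanging the group on the amide-type nitrogen leaves the number unchanged.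

Compound 4 `O=C(NS(=O)(=O)CCNCc1ccccc1)c1ccc(Nc2nc(NC3(c4ccc(Cl)cc4)CC3)nc(OCC(F)(F)F)n2)cc1` is not yet measured. It differs from compound 3 in one place: benzyl in place of isopropylcarbamoyl on an amine nitrogen. Going by the values given here, no measured step covers this exchange; the measured steps only show that adding the urea raised the number modestly and that altering its substituent did not matter. Compound 3 sits near the top of the read-out, so little room for a rise remains. Compound 4 is therefore expected to give 78%, with a range from 50% to 100%, the estimated step of a number 19 percentage points lower from compound 3 to compound 4 (beyond the scatter) being a modest fall with considerable uncertainty.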

Compound 4, percent of the compound remaining: 100%
Estimate against measurement, compound 4: 22 percentage points below, within the range that was stated.
By their numbers in this assay, from the lowest: compound 1; then compounds 3, 2 and 4 (each within the scatter of the next).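

In this assay, benzyl in place of isopropylcarbamoyl on the amine nitrogen gives a number 3 percentage points higher from compound 3 to compound 4 (within the scatter) and benzyl in place of methylcarbamoyl gives no change at the digits printed from compound 2 to compound 4 (within the scatter), so at this position a group with no hydrogen-bond donors or acceptors stands level with both ureas. With a number 15 percentage points higher from compound 1 to compound 4 (beyond the scatter), benzylamino on the saturated chain carbon matches what the two ureas did, and among these compounds the gain over compound 1 does not depend on a urea. No available evidence explains this result.

On these data alone, whether the plain primary amine or a carboxylic acid at this position would hold the number stays open. Compounds 2, 3 and 4 all lie close to the top of this read-out, which leaves little room to tell them apart.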